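Sulfonyl substituent swap in the urea series: clearance notes

The source may hold more compounds than are shown below. What is called first, only, known or untested is meant among the compounds shown, and "the series" means these compounds.

Measured in an ADME assay on microsomes from liver (Homo sapiens) for pharmacokinetics, read by LC-MS, with a stated time of 60 min, tested at 1 uM; on this read-out higher numbers stand for fast clearance and lower numbers for slow clearance:
Compound 1 `CCCn1cc(S(=O)(=O)c2ccc(CNC(=O)N3Cc4ccncc4C3)cc2)cn1` gives 11 mL/min/kg.
Compound 2 `CC(C)n1cc(S(=O)(=O)c2ccc(CNC(=O)N3Cc4ccncc4C3)cc2)cn1` gives 4 mL/min/kg.

Compound 2 holds the lowest of the two numbers; its nearest neighbour is compound 1, reached by a 2.8-fold lower number from compound 1 to compound 2 (0.44 log units; beyond the scatter).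

Compound 3 `O=C(NCc1ccc(S(=O)(=O)N2CCC[C@H](O)C2)cc1)N1Cc2ccncc2C1` differs from compound 2 by 3-hydroxypiperidin-1-yl in place of 1-isopropyl-1H-pyrazol-4-yl on a sulfonyl sulfur.

Going by the values given here, only one measured step exists, a 2.8-fold lower number from compound 1 to compound 2 (0.44 log units; beyond the scatter), and it concerns an alkyl exchange on an aromatic nitrogen, not the group on the sulfonyl sulfur, so it bears little on this change. For compound 3 a step of a 1.5-fold higher number from compound 2 to compound 3 (0.18 log units; within the scatter) in this assay is expected, upward but modest. The estimate for compound 3 is 6 mL/min/kg, within 3 mL/min/kg to 12 mL/min/kg.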

Compound 3, clearance: 8 mL/min/kg
Compound 3: the middle estimate sits 1.3-fold (0.12 log units) below what was measured; measured number inside the range.
By their numbers in this assay, from the lowest: compounds 2, 3 and 1 (each within the scatter of the next, the first and the last beyond it).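

In this assay, going by these compounds alone, the first change on the sulfonyl sulfur can be read: 3-hydroxypiperidin-1-yl in place of 1-isopropyl-1H-pyrazol-4-yl (a 2.0-fold higher number from compound 2 to compound 3 (0.30 log units; within the scatter)) and in place of 1-propyl-1H-pyrazol-4-yl (a 1.4-fold lower number from compound 1 to compound 3 (0.14 log units; within the scatter)). Both steps lie within the scatter, so a non-aromatic ring stands in for the aromatic one with no readable shift in clearance. Nothing available gives a reason for these numbers.

From the compounds shown here alone, what an unsubstituted piperidin-1-yl or a morpholin-4-yl would give on the sulfonyl sulfur stays open, as does the part played by the defined stereocentre.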